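Halogen exchange on the shared core: cytotoxicity notes

This account rests on a few compounds, and the source may have more. Where it says the series, first, only, none or still open, it means among the compounds named here.

Compound 1 `C=C1C(n2cc(F)c(=O)[nH]c2=O)O[C@H](CO)[C@@H]1O` in a functional assay on L1210 cells (Mus musculus) for cytotoxicity (a lower number here means a stronger inhibitor, a higher number a weaker inhibitor), gives > 100 ug/mL, which is a limit of the assay and not a number.
Compound 2 `C=C1C(n2cc(Cl)c(=O)[nH]c2=O)O[C@H](CO)[C@@H]1O` in this assay gives > 100 ug/mL, again a limit.

Going by the values given here, compound 2 thus stands at the limit, with no number read for it, and the one further value shown, that of compound 1, is likewise a limit. The step that the two limits leave unreadable from compound 1 to compound 2 cannot be read from two limits. Compound 3 `C=C1C(n2cc(Br)c(=O)[nH]c2=O)O[C@H](CO)[C@@H]1O` differs from compound 2 by bromo in place of chloro on an aromatic carbon. Among the compounds with values here, the only measured step, that from compound 1 to compound 2, bears on this change as another halogen exchange, but its size is not readable, so no direction beyond the scatter can be stated; both measured values sit at the limit of > 100 ug/mL in this assay, at which 2 of the 2 values shown sit. Compound 3 is therefore expected to return a limit as well, the expected step that the limit leaves unreadable from compound 2 to compound 3 carrying little weight. For compound 3 the estimate is 150 ug/mL, in the range 50 ug/mL to 500 ug/mL.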

Compound 3, half-maximal inhibitory concentration: > 100 ug/mL
Compound 3: a limit, no number; the forecaster's own chance of this, stated with the estimate: 85%; the middle value lies beyond the limit too.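

Compound 3, like compound 1 and compound 2, returns a limit and not a number, so no step among the three can be read: the limit of > 100 ug/mL in this assay, at which 3 of the 3 values shown sit.

What the compounds shown leave open is whether any halogen exchange on the shared core changes cytotoxicity in this assay, since no number stands for any of them.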